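This account rests on a few compounds, and the source may have more. Where it says the series, first, only, none or still open, it means among the compounds named here.

Compound 1 `COc1cc(C)cc(-c2c(-c3ccnc(-c4ccc(C(C)=O)cc4)c3)cnn2CC#N)c1`: 81%
Compound 2 `COc1cc(C)cc(-c2nn(CC#N)cc2-c2ccc(-c3cccc(C(C)=O)c3)nc2)c1`: 82%

In a functional assay on NCI-H522 cells (Homo sapiens) for cytotoxicity, read by sulforhodamine B assay, with a stated time of 48 h, tested at 0.01 uM (a lower number here means a stronger effect, a higher number a weaker effect of the compound at the concentration tested), compound 1 gives 81%, the lower of the two numbers on record, while compound 2 gives 82%; the gap between them lies within the scatter, so the two compounds read alike, both leaving most of the cell growth intact at this concentration. Compound 3 `COc1cc(C)cc(-c2c(-c3ccnc(-c4ccc(N(C)C)cc4)c3)cnn2CC#N)c1` is not yet measured. It differs from compound 1 in one place: dimethylamino in place of acetyl on an aromatic carbon. Going by the values given here, no pair of measured compounds shows this exchange, so nothing measured tells how the step should run. With both measured numbers sitting close together, the expectation for compound 3 in this assay is a step of no size beyond the scatter, estimated as a number 1 percentage points lower from compound 1 to compound 3 (within the scatter). Compound 3 is therefore expected to give about 80%, in a range from 65% to 95%.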

Compound 3, a percentage reported as activity, at one concentration (the size of the read-out at that concentration, not a potency): -7%
For compound 3 the middle estimate is 87 percentage points above the measured one; the measured number lies below the stated range.
By their numbers in this assay, from the lowest: compound 3; then compounds 1 and 2 (each within the scatter of the next).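

In this assay, the terminal aromatic ring para to a large group proves highly sensitive to what it carries: dimethylamino in place of acetyl gives a number 88 percentage points lower from compound 1 to compound 3 (beyond the scatter), a change that compounds 1 and 2, both bearing acetyl, could not reveal. The two groups match in heavy-atom count and hydrogen-bond acceptor count, and neither has a ring or a net charge, so these counts do not separate them; they differ in nitrogen for oxygen and in the double bond outside aromatic rings. Nothing shown explains the size of the step.

Going by these compounds, it remains open whether the step is specific to dimethylamino or would also appear with a primary amine, methoxy or pyrrolidine on the same carbon. On these data alone, whether dimethylamino would act likewise in place of the acetyl of compound 2 also remains open.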